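A few compounds are considered here, and "the series" means these few. Any claim that something is new, unique, unknown or untested is made for them only; others in the source may bear on it.

Working notes on the series.

Compound 1 `CO[C@@H]1O[C@H](COc2cccc(C(C)C)c2)[C@@H](O)[C@H](O)[C@H]1Oc1ccc(OC2CCCCC2)cc1` and compound 2 `CO[C@@H]1O[C@H](COc2ccccc2C(C)C)[C@@H](O)[C@H](O)[C@H]1Oc1ccc(OC2CCCCC2)cc1` share one core; compound 3 `CO[C@H]1O[C@H](COc2ccc(-c3ccccc3)cc2)[C@@H](O)[C@H](O)[C@H]1Oc1cccc(C(C)C)c1` and compound 4 `CO[C@H]1O[C@H](COc2ccc(-c3ccccc3)cc2)[C@@H](O)[C@H](O)[C@H]1Oc1ccccc1C(C)C` share another, and the difference between the two cores is not broken down here. In a functional assay on MDA-MB-231 cells (Homo sapiens) for cytotoxicity, read by MTT assay, with a stated time of 48 h (a lower number here means that less compound is needed, a higher number that more compound is needed for the effect), compound 1 gives 40000 nM, compound 2 gives 44000 nM and compound 3 gives 30000 nM. The change 2-isopropylphenyl in place of 3-isopropylphenyl on an oxygen on a saturated carbon gives a 1.1-fold higher number from compound 1 to compound 2 (0.04 log units; within the scatter). The change 2-isopropylphenyl in place of 3-isopropylphenyl on an oxygen on a saturated carbon is the same kind of change; it differs only in its surroundings, the place being on an oxygen on a saturated carbon whose other neighbours are a saturated ring carbon rather than a saturated chain carbon. Because compound 1 to compound 2 gives a 1.1-fold higher number from compound 1 to compound 2 (0.04 log units; within the scatter), the step from compound 3 to compound 4 in this assay is expected to be small, a 1.1-fold higher number from compound 3 to compound 4 (0.04 log units; within the scatter). Compound 4 is therefore estimated at 33000 nM in this assay, between 15000 nM and 75000 nM.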

Compound 4, half-maximal effective concentration: 34000 nM
For compound 4 the middle estimate is 1.0-fold (0.01 log units) below the measured one; low and high end bracket the measured number.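

In this assay the swap of 3-isopropylphenyl for 2-isopropylphenyl gives a 1.1-fold higher number from compound 3 to compound 4 (0.05 log units; within the scatter) on the core of compound 3, and it reads the same on the core of compound 1: the same change on two cores in this assay, a 1.1-fold higher number (0.04 log units; within the scatter) from compound 1 to compound 2 and a 1.1-fold higher number (0.05 log units; within the scatter) from compound 3 to compound 4, 1.0-fold (0.01 log units) apart, within the scatter of two such steps. On these two cores the change therefore carries over as a step within the scatter, with no sign that the core alters it. Going by these compounds alone, neither step lies beyond the scatter, so this shows only that the change stays small on both cores, not that a larger step would carry over or that other cores would behave alike.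

The compounds shown leave open how an amine or a carboxylic acid in place of isopropyl would read in this assay and whether such a step would match on both cores. The difference between the two cores also remains unresolved.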